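The compounds below may be only part of what the source reports. "The series", "measured", "known", "first", "only" and "open" are said of these compounds alone.

Measured compounds:
Compound 1 `CC(=O)N1CCN=C(c2cccc(Cl)c2)c2c(C)nn(C)c21`. In a functional assay on the whole organism for positive allosteric modulation, with Rattus norvegicus as the target (a higher number here means that more compound is needed for the effect, a lower number that less compound is needed), compound 1 gives > 10 mg/kg, which is a limit of the assay and not a number.
Compound 2 `Cc1nn(C)c2c1C(c1cccc(Cl)c1)=NCCN2CCCN(C)C`. In this assay compound 2 gives > 10 mg/kg, again a limit of the assay rather than a number.

Compound 2 therefore stands only at a limit in this assay; no number for it is known. Going by the values given here, the single step measured so far, a step that the two limits leave unreadable from compound 1 to compound 2, cannot be read in size or direction, since both values sit at the limit of > 10 mg/kg in this assay, at which 2 of the 2 values shown sit.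

Compound 3 `Cc1cccc(C2=NCCN(CCCN(C)C)c3c2c(C)nn3C)c1` differs from compound 2 by methyl in place of chloro on an aromatic carbon. Among the compounds with values here, no measured step bears on this change: the one step in hand is unreadable, and it concerns a different part of the core. The change itself is small, one heavy atom for one heavy atom, with no ring, donor or acceptor entering or leaving. The expected step that the limit leaves unreadable from compound 2 to compound 3 is therefore none beyond the scatter, and compound 3 is most likely to remain at a limit. For compound 3 the estimate in this assay is 15 mg/kg, with a range from 5 mg/kg to 50 mg/kg.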

Compound 3, minimum effective dose: > 10 mg/kg
Compound 3: no number, only a limit; the forecaster's own chance of this, stated with the estimate: 70%; the middle value is on the limit's open side.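

No step can be read from compound 2 to compound 3, and the earlier step from compound 1 to compound 2 stays equally unreadable, since each value is a limit of the assay and not a number: the limit of > 10 mg/kg in this assay, at which 3 of the 3 values shown sit.

The compounds shown leave open how 3-chlorophenyl and 3-methylphenyl compare in this assay, and whether any change to this series gives a numerical minimum effective dose.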